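Methyl to Hydrogen Across Two Related Cores

The compounds below may be only part of what the source reports. "The series", "measured", "known", "first", "only" and "open" are said of these compounds alone.

Measured compounds:
compound 1, `O=C1C(Nc2ccccc2)=CC(=O)c2c1nc1n2[C@H]2OC[C@@H](O)[C@H]2OC1`, 3560 nM in a functional assay on ECa-109 cells for inhibition, with ECa-109 cell line (Homo sapiens) as the target, read by sulforhodamine B assay; a lower number here means a stronger inhibitor, a higher number a weaker inhibitor
compound 2, `Cc1ccc(NC2=CC(=O)c3c(nc4n3[C@H]3OC[C@@H](O)[C@H]3OC4)C2=O)cc1`, > 4000 nM
compound 3, `Cc1ccc(NC2=CC(=O)c3nc4n(c3C2=O)[C@H]2OC[C@@H](O)[C@H]2OC4)cc1`, 3480 nM

Compound 2 and compound 3 have the same atoms joined differently; the difference between the two cores is not broken down here. Among the measured compounds shown here, for compound 2 this assay reports only a limit, > 4000 nM, and it is the only one of the three values that is a limit, since (the limit of > 4000 nM in this assay, at which 1 of the 3 values shown sits). Compound 1 differs from compound 2 by hydrogen in place of methyl on an aromatic carbon, and this gives an at least 1.1-fold lower number from compound 2 to compound 1 (0.05 log units; that floor lies within the scatter); that step is a floor because of the limit of > 4000 nM in this assay, at which 1 of the 3 values shown sits. Compound 3 and compound 1 lie within the scatter of each other, so no order between them is claimed.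

Compound 4, `O=C1C=C(Nc2ccccc2)C(=O)c2c1nc1n2[C@H]2OC[C@@H](O)[C@H]2OC1`, has not yet been measured. It differs from compound 3 by hydrogen in place of methyl on an aromatic carbon, which is the same change as that from compound 2 to compound 1. For the measured compounds named here, on the core of compound 3 the effect of this change is unknown, and the only measured example of it gives a step whose floor lies within the scatter. The number for compound 4 is therefore expected to stay close to compound 3, with an expected step of a 1.2-fold lower number from compound 3 to compound 4 (0.06 log units; within the scatter). This expectation rests on the value of compound 3, 3480 nM, and on an at least 1.1-fold lower number from compound 2 to compound 1 (0.05 log units; that floor lies within the scatter). The estimate for compound 4 in this assay is 3000 nM, expected to fall between 1200 nM and 8000 nM.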

Compound 4, half-maximal inhibitory concentration: 4970 nM
Compound 4: the middle estimate sits 1.7-fold (0.22 log units) below what was measured, and the stated range covers the measured number.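

Taking the methyl off the 4-methylphenyl group on the second core gives a 1.4-fold higher number from compound 3 to compound 4 (0.15 log units; within the scatter) in this assay, so on this core the change to phenyl has no effect that can be told from the scatter. Set beside the only other example of the same change, the comparison reads: the same change on two cores in this assay, an at least 1.1-fold lower number (0.05 log units; that floor lies within the scatter) from compound 2 to compound 1 and a 1.4-fold higher number (0.15 log units; within the scatter) from compound 3 to compound 4; the limit leaves it open whether they differ. This does not show that the change carries over from one core to the other with the same size, nor that its size differs between them, because compound 2 has only a limit in place of a number: the limit of > 4000 nM in this assay, at which 1 of the 4 values shown sits.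

All four compounds carry either hydrogen or methyl at this place, para to a large group, leaving open how a methoxy group, a chlorine atom or an amine there would read on either core. On these data alone, it also stays open whether any replacement at this place that gave a step beyond the scatter on one core would give a similar step on the other.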